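A few compounds are considered here, and "the series" means these few. Any claim that something is new, unique, unknown or untested is made for them only; others in the source may bear on it.

Working notes on the series. All three measured compounds share one core and differ only on the aromatic ring attached through the amine. Compound 1 `O=[N+]([O-])c1ccc2nc(CNc3ccccc3)cnc2c1` gives 56000 nM in a functional assay on PC-3 cells (Homo sapiens) for cytotoxicity, read by MTT assay, with a stated time of 96 h; on this read-out lower numbers stand for stronger inhibition and higher numbers for weaker inhibition. Compound 2 `Cc1ccc(NCc2cnc3cc([N+](=O)[O-])ccc3n2)cc1` gives 57000 nM in this assay, and compound 3 `O=[N+]([O-])c1ccc2nc(CNc3ccc(Cl)cc3)cnc2c1` gives 70000 nM in this assay. Compound 3 does not separate from the other two: a 1.3-fold higher number from compound 1 to compound 3 (0.10 log units; within the scatter) and a 1.2-fold higher number from compound 2 to compound 3 (0.09 log units; within the scatter), both within the scatter, as is a 1.0-fold higher number from compound 1 to compound 2 (0.01 log units; within the scatter). Compound 4 `O=C(O)c1ccc(NCc2cnc3cc([N+](=O)[O-])ccc3n2)cc1` differs from compound 3 by carboxy in place of chloro on an aromatic carbon. Within the data shown here, no measured step introduces a carboxy, so nothing bears on this change directly; the three steps that exist, each a substituent change on the same ring, all stay within the scatter, and the series gives no ground to expect a step beyond the scatter in this assay here either. The expected step is therefore no change at the digits printed from compound 3 to compound 4 (within the scatter). Compound 4 is estimated at 70000 nM in this assay, with a range from 25000 nM to 200000 nM.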

Compound 4, half-maximal inhibitory concentration: 45000 nM
For compound 4 the middle estimate is 1.6-fold (0.19 log units) above the measured one; the range from low to high includes it.
By their numbers in this assay, from the lowest: compounds 4, 1, 2 and 3 (each within the scatter of the next).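

Among these compounds, on an aromatic carbon para to a large group, carboxy is the first substituent here to bring a hydrogen-bond donor and a hydrogen-bond acceptor, and it adds more heavy atoms than chloro, yet this assay still shows no step beyond the scatter (a 1.6-fold lower number from compound 3 to compound 4 (0.19 log units; within the scatter)). The same holds against methyl (a 1.3-fold lower number from compound 2 to compound 4 (0.10 log units; within the scatter)) and against hydrogen (a 1.2-fold lower number from compound 1 to compound 4 (0.09 log units; within the scatter)), so all four compounds now stand within the scatter of one another, across a wider range of substituents than the earlier three covered. Nothing available accounts for this flat result.

From the compounds shown here alone, whether an amine, an amide or a longer chain at this position would give a step beyond the scatter stays open. So does whether any change to the shared core would move the number at all.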